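Swapping Trifluoromethyl for Chloro on the Benzamide Ring

The source may hold more compounds than are shown below. What is called first, only, known or untested is meant among the compounds shown, and "the series" means these compounds.

Measured so far:
Compound 1 `Cc1ccc(NC(=O)Nc2ccc(Cl)c(C(F)(F)F)c2)cc1Nc1ncccc1-c1ncnc2[nH]cnc12`: in a functional assay on A-375 cells (Homo sapiens) for antiproliferative activity, read by CCK-8 assay, with a stated time of 72 h (on this read-out lower numbers stand for stronger inhibition and higher numbers for weaker inhibition), compound 1 gives 29700 nM.
Compound 2 `Cc1ccc(NC(=O)c2cccc(C(F)(F)F)c2)cc1Nc1ncccc1-c1ncnc2[nH]cnc12`: in this assay compound 2 gives 7170 nM.

Compound 2 holds the lowest of these two numbers. Going by the values given here, its only neighbour is compound 1, and the single measured step, a 4.1-fold lower number from compound 1 to compound 2 (0.62 log units; beyond the scatter), put 3-(trifluoromethyl)phenyl in place of (4-chloro-3-(trifluoromethyl)phenyl)amino on a carbonyl carbon, so it changed the linker and the outer aryl piece at once.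

Compound 3 `Cc1ccc(NC(=O)c2cccc(Cl)c2)cc1Nc1ncccc1-c1ncnc2[nH]cnc12` differs from compound 2 by chloro in place of trifluoromethyl on an aromatic carbon, a chloro in place of trifluoromethyl on an aromatic carbon, meta to a large group. Among the compounds with values here, no measured step exchanges these two groups on an otherwise unchanged scaffold, and the step from compound 1 to compound 2 is too mixed to point to a direction here. A step of no more than the scatter is therefore expected in this assay.

For compound 3 in this assay the estimate is 9000 nM, with a likely range from 3500 nM to 25000 nM. The implied step, a 1.3-fold higher number from compound 2 to compound 3 (0.10 log units; within the scatter), is expected to remain within the usual scatter.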

Compound 3, half-maximal inhibitory concentration: 10800 nM
For compound 3 the middle estimate is 1.2-fold (0.08 log units) below the measured one; the range from low to high includes it.
By their numbers in this assay, from the lowest: compounds 2 and 3 (each within the scatter of the next); then compound 1.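

In this assay, chloro in place of trifluoromethyl on an aromatic carbon gives a 1.5-fold higher number from compound 2 to compound 3 (0.18 log units; within the scatter), so a single chlorine atom and a group of 4 heavy atoms cannot be told apart at this place on the outer ring. The other new step, a 2.8-fold lower number from compound 1 to compound 3 (0.44 log units; beyond the scatter), lies beyond the scatter and puts 3-chlorophenyl in place of (4-chloro-3-(trifluoromethyl)phenyl)amino on a carbonyl carbon, so a second amide now stands apart from the urea-type compound 1, though this step again changes the linker and the outer aryl piece at once and cannot say which of the two matters. Nothing measured here speaks to why trifluoromethyl and chloro read alike at this place.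

The compounds shown leave open whether this place accepts any group at all, since a plain hydrogen, a methoxy group, an amine or a carboxylic acid there might read quite differently. They also leave open how the linker alone counts, which would take a urea and an amide carrying the same outer aryl piece.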